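The source may hold more compounds than are shown below. What is called first, only, known or untested is meant among the compounds shown, and "the series" means these compounds.

Of the compounds shown here, three built on the same core have been measured in an ADME assay on HEK293 cells (Homo sapiens) for cytotoxicity, read by CCK-8 assay and cell counting, with a stated time of 2 days; on this read-out lower numbers stand for stronger inhibition and higher numbers for weaker inhibition. Compound 1, `Oc1ccc(-c2cc(-c3ccc(Cl)cc3)nc(-c3cccnc3)c2)cc1`, gives 27500 nM in this assay. Compound 2, `Oc1ccc(-c2cc(-c3cccnc3)nc(-c3cccc(Cl)c3)c2)cc1`, gives 25700 nM. Compound 3, `Oc1ccc(-c2cc(-c3ccc(Cl)cc3)nc(-c3ccco3)c2)cc1`, gives 5720 nM, the lowest of the three numbers, and so compound 3 is the strongest inhibitor of the set measured so far.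

Compound 1 and compound 3 differ in one place: furan-2-yl in place of pyridin-3-yl on an aromatic carbon. This change gives a 4.8-fold lower number from compound 1 to compound 3 (0.68 log units; beyond the scatter). Compound 1 and compound 2 differ in another place: 3-chlorophenyl in place of 4-chlorophenyl on an aromatic carbon. This change gives a 1.1-fold lower number from compound 1 to compound 2 (0.03 log units; within the scatter), so compound 1 and compound 2 cannot be told apart in this assay.

Compound 4, `Oc1ccc(-c2cc(-c3cccc(Cl)c3)nc(-c3ccco3)c2)cc1`, has not yet been measured. It differs from compound 3 in a single place: 3-chlorophenyl in place of 4-chlorophenyl on an aromatic carbon. This is the same kind of change that separates compound 2 from compound 1, though the surroundings are not identical: in compound 1 the carbon carrying the change is meta to a pyridin-3-yl group, whereas in compound 3 it is meta to a furan-2-yl group.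

Among the measured compounds shown here, only one step is available to judge this change, and it is the flat one. The step from compound 3 to compound 4 is therefore expected to be small, a 1.0-fold lower number from compound 3 to compound 4 (0.02 log units; within the scatter), because of a 1.1-fold lower number from compound 1 to compound 2 (0.03 log units; within the scatter). Compound 4 is estimated at 5500 nM in this assay, with a likely range from 2500 nM to 12000 nM.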

Compound 4, half-maximal inhibitory concentration: 2880 nM
The estimate for compound 4 lay 1.9-fold (0.28 log units) above the measured number, and the stated range covers the measured number.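

In this assay, the 3-chlorophenyl for 4-chlorophenyl swap on the furan-2-yl compounds gives a 2.0-fold lower number from compound 3 to compound 4 (0.30 log units; within the scatter), so this swap stays within the scatter on the second core as it did on the first, and the two steps do not differ: the same change on two cores in this assay, a 1.1-fold lower number (0.03 log units; within the scatter) from compound 1 to compound 2 and a 2.0-fold lower number (0.30 log units; within the scatter) from compound 3 to compound 4, 1.9-fold (0.27 log units) apart, within the scatter of two such steps The furan-2-yl for pyridin-3-yl swap, read on the 3-chlorophenyl compounds, gives an 8.9-fold lower number from compound 2 to compound 4 (0.95 log units; beyond the scatter), and so it also carries over from one core to the other, with a step beyond the scatter on both: the same change on two cores in this assay, a 4.8-fold lower number (0.68 log units; beyond the scatter) from compound 1 to compound 3 and an 8.9-fold lower number (0.95 log units; beyond the scatter) from compound 2 to compound 4, 1.9-fold (0.27 log units) apart, within the scatter of two such steps This shows that, across these four compounds, each swap behaves much the same whichever form of the other group is present, but it rests on a single square of compounds and does not show that either swap would carry over to any other core, nor does it explain why the furan-2-yl compounds give the lower numbers.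

The compounds shown leave open what happens when the chlorine is replaced by fluorine, bromine or a methoxy group, or when the furan-2-yl group gives way to a thiophene or a plain phenyl ring. They also leave open how far the hydroxyl of the 4-hydroxyphenyl group, present in all four, matters, for instance against a methoxy group, an amine or a carboxylic acid at that place.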